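Replacing One Aromatic Group on the Ester Chain

A few compounds are considered here, and "the series" means these few. Any claim that something is new, unique, unknown or untested is made for them only; others in the source may bear on it.

Of the compounds shown here, three have been tested in a functional assay on the whole organism (strain Kunming) with Mus musculus as the target, with a stated time of 0.5 h, at a dose of 300 mg/kg by the intraperitoneal route; on this read-out higher numbers stand for a weaker effect at the one dose given and lower numbers for a stronger effect. Compound 1 `COc1ccccc1/C=C/C(=O)OC/C=C/c1cc(OC)c(OC)cc1OC` gives 50%, compound 2 `COc1cc(OC)c(OC)cc1/C=C/COC(=O)/C=C/c1ccccc1C(F)(F)F` gives 50%, and compound 3 `COc1cc(OC)c(OC)cc1/C=C/COC(=O)/C=C/c1cc(OC)c(OC)c(OC)c1` gives 25%. Among the measured compounds shown here, the only measured step between close relatives is no change at the digits printed from compound 1 to compound 2 (within the scatter), so exchanging methoxy for trifluoromethyl on the aromatic carbon left the read-out where it was. Compound 2 thus stands level with compound 1, the two together at the top of the three numbers, while compound 3 sits at a lower number, a gap that is beyond the scatter.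

Compound 4 `COc1cc(OC)c(OC)cc1/C=C/COC(=O)/C=C/c1ccc(F)cc1` has not yet been measured in this assay . It differs from compound 2 by 4-fluorophenyl in place of 2-(trifluoromethyl)phenyl on a double-bonded chain carbon bound to a double-bonded chain carbon. For the measured compounds named here, the one step that bears on this change, from compound 1 to compound 2, altered the same aromatic group and produced no change beyond the scatter. Going by the values given here, no measured step covers a fluorine atom on this ring, so the expectation leans on that single step alone. Compound 4 is therefore expected to give 50%, with a range from 30% to 70%. The expected step is no change at the digits printed from compound 2 to compound 4 (within the scatter), meaning no change beyond the scatter.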

Compound 4, a percentage reported as activity, at one dose (the size of the read-out at that dose, not a potency): 0%
Compound 4: middle estimate off by 50 percentage points, on the high side, outside the stated range (below it).
By their numbers in this assay, from the lowest: compound 4; then compound 3; then compounds 1 and 2 (each within the scatter of the next).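

Exchanging the aromatic group on a double-bonded chain carbon bound to a double-bonded chain carbon is not always silent in this assay: 4-fluorophenyl in place of 2-(trifluoromethyl)phenyl gives a number 50 percentage points lower from compound 2 to compound 4 (beyond the scatter), and 4-fluorophenyl in place of 2-methoxyphenyl gives a number 50 percentage points lower from compound 1 to compound 4 (beyond the scatter). Lower numbers here stand for a stronger effect, so this place in the molecule does respond to the group it carries, even though the earlier exchange gave no change at the digits printed from compound 1 to compound 2 (within the scatter). Nothing at hand explains why this group behaves so differently from the other two.

Each step swaps a whole substituted ring, so the compounds shown cannot tell whether the stronger effect belongs to the fluorine atom itself, to where it stands in 4-fluorophenyl, or simply to the absence of the groups that left. As far as these compounds go, a plain phenyl group, or a chlorine atom in place of the fluorine, would help separate these readings, and since the read-out comes from one dose, how far compound 4 exceeds its relatives in potency also stays open.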